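Trifluoromethoxy in Place of Chloro on a Kinase Inhibitor

The compounds below may be only part of what the source reports. "The series", "measured", "known", "first", "only" and "open" are said of these compounds alone.

Going by the values given here, compound 1 `Cc1c(C(=O)Nc2ccc(Oc3ncnc4[nH]cc(-c5ccccc5)c34)c(F)c2)c(=O)c2cc(Cl)ccc2n1C` is the only member of this set with a numerical result: in an assay on isolated protein for inhibition of tyrosine-protein kinase receptor UFO (Homo sapiens), read by FRET and Z'-LYTE, with a stated time of 1.5 h (a higher number here means a weaker inhibitor, a lower number a stronger inhibitor), compound 1 gives 1890 nM. Compound 2 `Cc1c(C(=O)Nc2ccc(Oc3ncnc4[nH]cc(-c5ccccc5)c34)c(F)c2)c(=O)c2ccc(Cl)cc2n1C` reaches only a limit of the assay, and in this assay compound 2 gives > 10000 nM. Compound 3 `CCc1ccc2c(c1)c(=O)c(C(=O)Nc1ccc(Oc3ccnc(Cl)c3)c(F)c1)c(C)n2C` likewise sits at a limit of the assay, and in this assay compound 3 gives > 10000 nM. Among the compounds with values here, two of the three results thus sit at the limit of > 10000 nM in this assay, at which 2 of the 3 values shown sit, so no step between measured compounds can be drawn, and compound 1 stands alone as the reference. Compound 4 `Cc1c(C(=O)Nc2ccc(Oc3ncnc4[nH]cc(-c5ccccc5)c34)c(F)c2)c(=O)c2cc(OC(F)(F)F)ccc2n1C` differs from compound 1 in one place: trifluoromethoxy in place of chloro on an aromatic carbon. Within the data shown here, with no measured step to lean on, this change is expected to shift the value in this assay by no more than the usual scatter, with the direction uncertain. Compound 4 is estimated at 2500 nM, within a range from 800 nM to 8000 nM. The expected step is a 1.3-fold higher number from compound 1 to compound 4 (0.12 log units; within the scatter), essentially flat.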

Compound 4, half-maximal inhibitory concentration: 74 nM
The estimate for compound 4 lay 34-fold (1.53 log units) above the measured number; the measured number lies below the stated range.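

In this assay, going by these compounds alone, trifluoromethoxy in place of chloro on an aromatic carbon gives a 26-fold lower number from compound 1 to compound 4 (1.41 log units; beyond the scatter) and provides the first readable step in this set. It shows that this position, meta to a fused ring and para to a fused ring on the six-membered aromatic ring of carbon only, responds strongly to the group it carries, and that the larger group is accepted there with a gain in inhibition. Nothing measured in this set gives a cause for that gain.

Whether the gain needs the oxygen or the fluorines stays open, since the compounds shown carry neither methoxy nor trifluoromethyl at this position. Steps involving compound 2 and compound 3 cannot be read, and their values are limits of the assay: the limit of > 10000 nM in this assay, at which 2 of the 4 values shown sit.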